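Methylsulfanyl for methylamino on the thiophen-3-yl analogue

The compounds below may be only part of what the source reports. "The series", "measured", "known", "first", "only" and "open" are said of these compounds alone.

Compound 1 `CSc1ncnc2c1c(-c1ccccc1)cn2[C@@H]1O[C@H](CO)[C@@H](O)[C@H]1O` carries methylsulfanyl together with a phenyl group; in a functional assay on K562 cells (Homo sapiens), read by MTT assay, with a stated time of 72 h (on this read-out higher numbers stand for weaker inhibition and lower numbers for stronger inhibition), compound 1 is reported only as a limit of the assay, > 20000 nM. Compound 2 `C#Cc1cn([C@@H]2O[C@H](CO)[C@@H](O)[C@H]2O)c2ncnc(NC)c12` carries methylamino together with ethynyl and gives 1380 nM in this assay. Compound 3 `CNc1ncnc2c1c(-c1ccsc1)cn2[C@@H]1O[C@H](CO)[C@@H](O)[C@H]1O` carries methylamino together with thiophen-3-yl, and in this assay compound 3 is likewise reported only as a limit, > 20000 nM. Going by the values given here, the single measured step, an at least 14-fold higher number from compound 2 to compound 3 (1.16 log units; beyond the scatter), concerns the group on the five-membered ring and not the change considered here. Two of the three values rest at the limit of > 20000 nM in this assay, at which 2 of the 3 values shown sit, so compound 3 stands at the weak end of what the numbers can resolve.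

Compound 4 `CSc1ncnc2c1c(-c1ccsc1)cn2[C@@H]1O[C@H](CO)[C@@H](O)[C@H]1O` differs from compound 3 by methylsulfanyl in place of methylamino on an aromatic carbon. Among the compounds with values here, no measured step covers this swap directly; compound 1, which also carries methylsulfanyl, is the only point of comparison, and its value is a limit. On that basis the step that the limit leaves unreadable from compound 3 to compound 4 is expected to be one the numbers cannot resolve, with the result most likely reported again as a limit. For compound 4 the estimate in this assay is 30000 nM, with a range from 8000 nM to 100000 nM.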

Compound 4, half-maximal inhibitory concentration: > 20000 nM
Compound 4 ended at the assay's limit (the forecaster's own chance of this, stated with the estimate: 85%); the middle value lies beyond the limit too.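

Compound 4 is reported in this assay only as a limit, > 20000 nM. The steps to it from compound 3 and from compound 1 cannot be read, as all three compounds sit at the same limit: the limit of > 20000 nM in this assay, at which 3 of the 4 values shown sit.

The compounds shown leave open whether methylsulfanyl and methylamino, or thiophen-3-yl and phenyl, differ at all in this assay.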